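This account rests on a few compounds, and the source may have more. Where it says the series, first, only, none or still open, it means among the compounds named here.

Three measured compounds, compound 1 `COc1ccc(-c2cc(=O)c3c(OC)cc(OC)cc3[nH]2)cc1`, compound 2 `COc1ccc(-c2cc(=O)c3c(OC)cc(OC)cc3n2S(=O)(=O)c2ccc([N+](=O)[O-])cc2)cc1` and compound 3 `COc1cc(OC)c2c(=O)cc(C(=O)Nc3ccc(N4CCN(C)CC4)cc3)[nH]c2c1`, share a core and were tested in a functional assay on HepG2 cells (Homo sapiens) for antiproliferative activity, with a stated time of 72 h; on this read-out higher numbers stand for an effect only at larger amounts of compound and lower numbers for an effect already at smaller amounts. Compound 1 gives > 31100 nM, a limit of the assay. Compound 2 gives > 29300 nM, also a limit. Compound 3 gives > 19800 nM, likewise a limit, so its place among the three cannot be ordered; it sits at the limit of > 19800 nM in this assay, at which 1 of the 3 values shown sits, while the other two sit at the limit of > 29300 nM in this assay, at which 1 of the 3 values shown sits, and (the limit of > 31100 nM in this assay, at which 1 of the 3 values shown sits). Compound 4, `COc1cc(OC)c2c(=O)cc(C(=O)Nc3ccc(Oc4ccc(F)cc4)cc3)[nH]c2c1`, differs from compound 3 by 4-fluorophenoxy in place of 4-methylpiperazin-1-yl on an aromatic carbon. For the measured compounds named here, no measured pair differs in one place, so no measured step guides the expectation. The step is expected to be an at least 2.4-fold lower number from compound 3 to compound 4 (0.39 log units; beyond the scatter), a gain beyond the scatter but uncertain. For compound 4 the estimate is 8000 nM, within 1500 nM to 40000 nM.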

Compound 4, half-maximal effective concentration: > 50000 nM
Compound 4: no number, only a limit (the forecaster's own chance of this, stated with the estimate: 45%); at least 6.2-fold (0.79 log units) between middle value and limit.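

Compound 3 and compound 4 both give only limits of the assay, so the step between them cannot be read. The compounds shown leave open how 4-fluorophenoxy and 4-methylpiperazin-1-yl compare, and whether any change to this series gives a measurable number.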